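Ester linker saturation: from compound 2 to compound 4

The source may report more compounds than this note shows. Statements on the series, on what has been measured and on what is new or still open speak of the compounds shown alone.

Compound 2 `CCOC(=O)/C=C/c1ccncc1-c1ccc2ccccc2c1` is the ethyl ester of the series. In an assay on a protein complex for inhibition of CDK8/Cyclin C (Homo sapiens), with a stated time of 1 h, tested at 10 uM (a lower number here means less inhibition, a higher number more inhibition at the concentration tested (going by the name of the read-out)), compound 2 gives 102%, the highest of the three numbers. Compound 3 `O=C(/C=C/c1ccncc1-c1ccc2ccccc2c1)N1CCOCC1` gives 99%, and the step of a number 3 percentage points lower from compound 2 to compound 3 (within the scatter) leaves the two indistinguishable. Going by the values given here, compound 1 `O=C(O)[C@@H]1CCCN1C(=O)/C=C/c1ccncc1-c1ccc2ccccc2c1` gives 67%; the steps of a number 35 percentage points higher from compound 1 to compound 2 (beyond the scatter) and a number 32 percentage points higher from compound 1 to compound 3 (beyond the scatter) set the 2-carboxypyrrolidin-1-yl member apart as the one with the lower number so far.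

Compound 4 `COC(=O)CCc1ccncc1-c1ccc2ccccc2c1` is not yet measured. Relative to compound 2 the change is 2-(methoxycarbonyl)ethyl in place of 2-(ethoxycarbonyl)ethenyl on an aromatic carbon. Among the compounds with values here, all three measured steps alter only the group on the carbonyl carbon; none touches the ethenyl link or the alkyl of the ester, so no measured step bears directly on this change. The measured steps show that the number is level whether the carbonyl carbon bears ethoxy or morpholin-4-yl, but they say nothing about the ethenyl link. The expected step is a number 27 percentage points lower from compound 2 to compound 4 (beyond the scatter), a provisional estimate with wide uncertainty. Compound 4 is expected to give 75%, within a range from 40% to 100%.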

Compound 4, a percentage reported as inhibition, at one concentration (the size of the read-out at that concentration, not a potency): 98%
The estimate for compound 4 lay 23 percentage points below the measured number, within the range that was stated.
By their numbers in this assay, from the lowest: compound 1; then compounds 4, 3 and 2 (each within the scatter of the next).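

In this assay, going by these compounds alone, the replacement of 2-(ethoxycarbonyl)ethenyl by 2-(methoxycarbonyl)ethyl on the aromatic carbon gives a number 4 percentage points lower from compound 2 to compound 4 (within the scatter) and so provides the first look at a change away from the group on the carbonyl carbon, with the number staying level. Among these compounds, the ethenyl link is therefore not needed for a number of this size at the concentration tested, although the same step also shortens the ester alkyl from ethyl to methyl, so the two edits can be read only together. No measurement at hand offers an explanation for this result.

Still open, as far as these compounds go, is whether the saturated link holds the number with a carboxylic acid, an amine or a longer chain in place of the methyl ester. A single-concentration read-out also leaves open whether compound 2 and compound 4 differ in potency.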